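Urea series: trifluoromethyl added to the chlorophenyl of compound 3

The source may report more compounds than this note shows. Statements on the series, on what has been measured and on what is new or still open speak of the compounds shown alone.

Measured so far in an ADME assay on isolated protein for inhibition of sodium-dependent dopamine transporter (Homo sapiens), tested at 10 uM; on this read-out higher numbers stand for more inhibition at the one concentration tested (going by the name of the read-out) and lower numbers for less inhibition:
compound 1 `O=C(NCCCCC(c1ccc(F)cc1)c1ccc(F)cc1)Nc1ccc(Cl)cc1`, 82%
compound 2 `COc1ccc(C(CCCCNC(=O)Nc2ccc(Cl)c(C(F)(F)F)c2)c2ccc(OC)cc2)cc1`, 75%
compound 3 `O=C(NCCCCN(c1ccc(F)cc1)c1ccc(F)cc1)Nc1ccc(Cl)cc1`, 68%

Compound 3 stands at the low end of the three numbers: the value of compound 1 lies beyond the scatter above it, whereas the value of compound 2 sits within the scatter of it, so no order between compound 2 and compound 3 is claimed. Among the measured compounds shown here, no pair of measured compounds differs in one place only, so no single step has been isolated yet.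

Compound 4 `O=C(NCCCCN(c1ccc(F)cc1)c1ccc(F)cc1)Nc1ccc(Cl)c(C(F)(F)F)c1` is the next compound to be measured in this assay. It is compound 3 with trifluoromethyl in place of hydrogen on an aromatic carbon. Compound 2, whose urea also carries 4-chloro-3-(trifluoromethyl)phenyl, gives a number within the scatter of compound 3, but its other half differs as well, so nothing is known about this change alone. The step is expected to be small, a number 4 percentage points higher from compound 3 to compound 4 (within the scatter), and not clearly beyond the scatter in either direction. Compound 4 is therefore estimated at 72%, between 58% and 85%.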

Compound 4, a percentage reported as inhibition, at one concentration (the size of the read-out at that concentration, not a potency): 85%
The estimate for compound 4 lay 13 percentage points below the measured number, and the stated range covers the measured number.
By their numbers in this assay, from the lowest: compounds 3, 2, 1 and 4 (each within the scatter of the next, the first and the last beyond it).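

In this assay, among the compounds shown here, trifluoromethyl in place of hydrogen on an aromatic carbon gives a number 17 percentage points higher from compound 3 to compound 4 (beyond the scatter), the first single change that can be read on its own. The position, ortho to a chloro group on the urea's aryl end, therefore takes the change from 4-chlorophenyl to 4-chloro-3-(trifluoromethyl)phenyl without a loss of inhibition at the one concentration tested, and the number responds to what sits there. The compounds shown carry no evidence on the reason for this step.

Whether the rise is specific to trifluoromethyl stays open, since a methyl, a nitrile or a methoxy group at this position is not among the compounds shown. Also open, as far as these compounds go, is whether the step depends on the chloro group or carries over to the core of compound 1.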